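Compound 1: (3-chlorophenyl)carbonyl for 2-fluorophenyl

The source may report more compounds than this note shows. Statements on the series, on what has been measured and on what is new or still open speak of the compounds shown alone.

Compound 1 `O=C(NNc1ccccc1F)c1ccc(NS(=O)(=O)c2cnc(O)nc2O)cc1` gives > 20000 nM (a limit)
Compound 2 `Cc1ccccc1NNC(=O)c1cccc(NS(=O)(=O)c2cnc(O)nc2O)c1` gives > 20000 nM (a limit)
Compound 3 `O=C(NNc1cccc(Cl)c1)c1ccccc1NS(=O)(=O)c1cnc(O)nc1O` gives 11800 nM

These three compounds were tested in a functional assay on MDA-MB-231 cells (Homo sapiens) for antiproliferative activity, read by MTT assay, with a stated time of 24 h (a lower number here means a stronger inhibitor, a higher number a weaker inhibitor), and only one of them returned a number. Compound 1 stands at the limit of > 20000 nM in this assay, at which 2 of the 3 values shown sit, and this is a limit, not a number. Compound 2 likewise gives the limit > 20000 nM and no number. Among the compounds with values here, compound 3 gives 11800 nM as the only measured number in the set.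

Compound 4 `O=C(NNC(=O)c1cccc(Cl)c1)c1ccc(NS(=O)(=O)c2cnc(O)nc2O)cc1` has not yet been measured. It carries (3-chlorophenyl)carbonyl in place of 2-fluorophenyl on an amine nitrogen, and the rest of compound 1 stays the same (difference: (3-chlorophenyl)carbonyl in place of 2-fluorophenyl on an amine nitrogen). Within the data shown here, no measured pair in the set differs in one place, so the size of this step cannot be read from an earlier one. In this assay a small step, none beyond the scatter and with no favoured direction, is expected (estimated step an at least 1.1-fold lower number from compound 1 to compound 4 (0.04 log units; that floor lies within the scatter)). The expectation leans on compound 3, which gives 11800 nM and so leaves a measurable value for compound 4 possible. For compound 4 the estimated value is 18000 nM (expected range 8000 nM to 30000 nM).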

Compound 4, half-maximal inhibitory concentration: 4160 nM
The estimate for compound 4 lay 4.3-fold (0.64 log units) above the measured number, outside the stated range (below it).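

In this assay, within the data shown here, (3-chlorophenyl)carbonyl in place of 2-fluorophenyl on an amine nitrogen gives an at least 4.8-fold lower number from compound 1 to compound 4 (0.68 log units; beyond the scatter), the first step in the set that can be read in one place and one that lies beyond the scatter. Among these compounds, this shows that the group on this amine nitrogen can move the read-out, which the earlier compounds could not show, as no two of them differed in one place only. The step has a floor but no upper bound, as its starting value is a limit and not a number: the limit of > 20000 nM in this assay, at which 2 of the 4 values shown sit.

The change swaps several features at once, bringing in a carbonyl and a chlorine and removing a fluorine, and the compounds shown do not tell which of these carries the step. On these data alone, a plain phenylcarbonyl, an acetyl group or a (3-fluorophenyl)carbonyl on the same nitrogen would begin to separate these parts, and how far the step depends on the rest of the core of compound 1 also stays open.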